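Replacing the sulfonamide on the benzylic amide series

The source may hold more compounds than are shown below. What is called first, only, known or untested is meant among the compounds shown, and "the series" means these compounds.

Compound 1 `CC(C)(C)c1ccc(C(=O)NCc2ccc(NS(C)(=O)=O)cc2)cc1` is the reference point of this set. In an assay on HeLa cells with Bile acid receptor (Homo sapiens) as the target, read by a luciferase reporter, with a stated time of 24 h (on this read-out lower numbers stand for an effect already at smaller amounts and higher numbers for an effect only at larger amounts of compound), compound 1 gives 44 nM, the second highest of the three numbers to hand. Going by the values given here, compound 2 `CC(C)(C)c1ccc(C(=O)NCc2ccc(NC(=O)C(F)(F)F)cc2Cl)cc1` gives 14 nM, a lower number that lies beyond the scatter of the method, while compound 3 `O=C(O)c1ccc(CNC(=O)c2ccc3ccccc3c2)cc1` gives 1360 nM, a far higher number; compound 3 also carries a different core and a carboxylic acid, so its value says little about the single change considered here. Compound 4 `CC(C)(C)c1ccc(C(=O)NCc2ccc(SC(F)(F)F)cc2)cc1` is not yet measured. It differs from compound 1 in one place ((trifluoromethyl)sulfanyl in place of methanesulfonamido on an aromatic carbon); a hydrogen-bond donor leaves and none enters. Among the compounds with values here, no pair of measured compounds shows this change, so the step from compound 1 to compound 4 is uncharted. Within the data shown here, the expectation is a modest move toward a higher number, of a size near the edge of the scatter, a 2.3-fold higher number from compound 1 to compound 4 (0.36 log units; beyond the scatter), since none of the measured values speaks directly to the loss of the donor. For compound 4 the expected value in this assay is 100 nM, estimated to fall between 25 nM and 400 nM.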

Compound 4, half-maximal effective concentration: 0.4 nM
Compound 4: middle estimate off by 250-fold (2.40 log units), on the high side, and the stated range ends above it.
By their numbers in this assay, from the lowest: compound 4; then compound 2; then compound 1; then compound 3.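

Going by these compounds alone, at this aromatic carbon, para to a large group, (trifluoromethyl)sulfanyl in place of methanesulfonamido gives in this assay the first single-place step, a 110-fold lower number from compound 1 to compound 4 (2.04 log units; beyond the scatter). Within the data shown here, a low number on this core therefore does not depend on the hydrogen-bond donor of methanesulfonamido, which the earlier compounds, with no pair differing in one place, could not show. Nothing measured here bears on the reason for the size of this step.

The compounds shown do not separate the contribution of the sulfur link from that of the trifluoromethyl end of the new group. From the compounds shown here alone, a methylsulfanyl, trifluoromethoxy or plain trifluoromethyl group on the same carbon of the same core would address that question, and whether a chlorine on the ring adds anything to compound 4 also remains open.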